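Series notes: step from compound 3 to compound 4

A few compounds are considered here, and "the series" means these few. Any claim that something is new, unique, unknown or untested is made for them only; others in the source may bear on it.

Measured so far:
compound 1 `O=C(NC[C@@H]1C[C@@H]2C=C[C@@H]1C2)NS(=O)(=O)N1CCC(CCNC(=O)c2cc(Cl)ccn2)CC1` — 32%
compound 2 `COc1ccc2nccc(C(=O)NCCC3CCN(S(=O)(=O)NC(=O)NC[C@@H]4C[C@@H]5C=C[C@@H]4C5)CC3)c2c1` — 10%
compound 3 `O=C(NC1CCCCC1)NS(=O)(=O)N1CCC(CCNC(=O)c2cc(Cl)cc3cccnc23)CC1` — 52%

In a functional assay on the whole organism (blood) with Rattus norvegicus as the target, with stated times of 24 h and 1 h, at a dose of 5 mg/kg by the intraperitoneal route (a higher number here means a stronger effect of the compound at the dose given, a lower number a weaker effect), compound 3 stands highest of the three numbers; its nearest neighbour is compound 1, and compound 2 lies furthest away, both gaps beyond the scatter. Going by the values given here, the single measured step, a number 22 percentage points lower from compound 1 to compound 2 (beyond the scatter), concerns a change on a carbonyl carbon and leaves the amide nitrogen untouched, so it does not bear on the step under consideration here.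

Compound 4 `O=C(NC[C@@H]1C[C@@H]2C=C[C@@H]1C2)NS(=O)(=O)N1CCC(CCNC(=O)c2cc(Cl)cc3cccnc23)CC1` differs from compound 3 by a group of 8 heavy atoms (8 carbon; 2 five-membered non-aromatic rings of carbon only) in place of a group of 6 heavy atoms (6 carbon; one six-membered non-aromatic ring of carbon only), on an amide-type nitrogen. Among the compounds with values here, no measured step covers this exchange. Within the data shown here, compound 1 carries the same entering group on that nitrogen, but it also differs from compound 3 at the carbonyl carbon, so the two values show only that compound 1 sits well below compound 3 without separating the two changes.

Among the measured compounds shown here, with no step to lean on, the direction is open. The step from compound 3 to compound 4 is expected to be modest, estimated as a number 12 percentage points lower from compound 3 to compound 4 (beyond the scatter), with wide uncertainty in both directions. Compound 4 is therefore estimated at 40%, with a range from 15% to 65%.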

Compound 4, a percentage reported as activity, at one dose (the size of the read-out at that dose, not a potency): 35%
Estimate against measurement, compound 4: 5 percentage points above; low and high end bracket the measured number.
By their numbers in this assay, from the lowest: compound 2; then compounds 1 and 4 (each within the scatter of the next); then compound 3.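

In this assay the exchange of cyclohexyl for the group of 8 heavy atoms with 2 five-membered non-aromatic rings, on the amide-type nitrogen with 6-chloroquinolin-8-yl held fixed on the carbonyl carbon, gives a number 17 percentage points lower from compound 3 to compound 4 (beyond the scatter) as a modest loss, so this position affects the read-out on its own. With that entering group held fixed, the carbonyl carbon gives two different results: 6-chloroquinolin-8-yl in place of 4-chloropyridin-2-yl gives a number 3 percentage points higher from compound 1 to compound 4 (within the scatter) and so no difference that can be read, whereas 6-chloroquinolin-8-yl in place of 6-methoxyquinolin-4-yl gives a number 25 percentage points higher from compound 2 to compound 4 (beyond the scatter) as a clear gain. Nothing available explains either the loss on the nitrogen or the pattern on the carbonyl carbon.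

From the compounds shown here alone, it remains open whether the loss on the nitrogen comes with the double bond of the entering group or with its ring system, which a saturated analogue of that group or an open-chain hexyl on the same nitrogen would help to separate. Going by these compounds, it is also open whether cyclohexyl paired with 4-chloropyridin-2-yl or with 6-methoxyquinolin-4-yl would follow the same order on the carbonyl carbon.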